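Swap at the ring amine nitrogen: compound 2 to compound 3

A few compounds are considered here, and "the series" means these few. Any claim that something is new, unique, unknown or untested is made for them only; others in the source may bear on it.

Compound 1 `CC(C)(C)OC(=O)N1CCC[C@@H]1C(=O)N1CCC(NS(=O)(=O)c2cc(S(=O)(=O)c3ccccc3)ccc2C(F)(F)F)CC1`: 120 nM
Compound 2 `CN(C)c1ccc(C(=O)N2CCC[C@H]2C(=O)N2CCC(NS(=O)(=O)c3cc(S(=O)(=O)c4ccccc4)ccc3C(F)(F)F)CC2)cc1`: 110 nM

In an assay on isolated protein for binding affinity to secreted frizzled-related protein 1 (Homo sapiens), read by fluorescence (a higher number here means a weaker inhibitor, a lower number a stronger inhibitor), compound 1 gives 120 nM and compound 2 gives 110 nM; the two numbers lie within the scatter of each other, so compound 2 stands alongside compound 1 rather than apart from it. Compound 3 `O=C([C@@H]1CCCN1Cc1ccccc1)N1CCC(NS(=O)(=O)c2cc(S(=O)(=O)c3ccccc3)ccc2C(F)(F)F)CC1` is not yet measured. The change is benzyl in place of (4-(dimethylamino)phenyl)carbonyl on an amine nitrogen in a ring. Compound 1 and compound 2 carry different groups on an amine nitrogen in a ring yet give close numbers, so the step of a 1.8-fold higher number from compound 2 to compound 3 (0.26 log units; within the scatter) is expected to be small, toward weaker binding, barely beyond the scatter. Compound 3 is expected at 200 nM, range 60 nM to 700 nM.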

Compound 3, half-maximal inhibitory concentration: 1400 nM
The estimate for compound 3 lay 7.0-fold (0.85 log units) below the measured number, outside the stated range (above it).
By their numbers in this assay, from the lowest: compounds 2 and 1 (each within the scatter of the next); then compound 3.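

On an amine nitrogen in a ring, the group is not interchangeable in this assay: benzyl in place of (4-(dimethylamino)phenyl)carbonyl gives a 13-fold higher number from compound 2 to compound 3 (1.10 log units; beyond the scatter). The comparison with the tert-butoxycarbonyl compound gives a 12-fold higher number from compound 1 to compound 3 (1.07 log units; beyond the scatter), so the two compounds with a carbonyl on this nitrogen stay together while the benzyl compound stands apart. No available evidence accounts for this loss.

Still open, on these data alone, is whether the carbonyl itself matters or the rest of the group. A plain benzoyl group on this nitrogen would separate the two.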